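Deleting the acetyl group: expected clearance of compound 3

The source may hold more compounds than are shown below. What is called first, only, known or untested is meant among the compounds shown, and "the series" means these compounds.

Two compounds of the shared core carry numbers in an ADME assay (liver) for metabolic stability, with Liver microsome (Homo sapiens) as the target, read by LC-MS, using microsomes, tested at 1 uM; on this read-out lower numbers stand for slow clearance and higher numbers for fast clearance. Compound 1 `CNc1nc(NCCCN(C)C)c2sc(-c3ccc(C(C)=O)cc3)cc2n1` stands highest of the two; in this assay compound 1 gives 81 uL/min. Compound 2 `CNc1nc(NCCCN(C)C)c2sc(-c3ccc(C(F)(F)F)cc3Cl)cc2n1`, which carries a trifluoromethyl and a chloro on the pendant ring, sits well lower, and in this assay compound 2 gives 13 uL/min, a gap beyond the scatter. Compound 3 `CNc1nc(NCCCN(C)C)c2sc(-c3ccccc3)cc2n1` has not been measured. It differs from compound 1 in one place: hydrogen in place of acetyl on an aromatic carbon. Going by the values given here, no measured pair in the set differs only by this change, so the size of the step cannot be read from any neighbour, and compound 2 carries two other changes at once, so it gives no direct guide either. Given that compound 1 shows fast clearance at 81 uL/min, the expectation for compound 3 is a number not far from it, if anything somewhat lower, with the step of a 1.4-fold lower number from compound 1 to compound 3 (0.13 log units; within the scatter) expected to stay within the scatter. Compound 3 is therefore estimated at 60 uL/min, within a range from 25 uL/min to 150 uL/min.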

Compound 3, intrinsic clearance in a liver preparation (reported as CLH), per the amount of preparation that the assay uses: 5 uL/min
Estimate against measurement, compound 3: 12-fold (1.08 log units) above; the measured number lies below the stated range.
By their numbers in this assay, from the lowest: compound 3; then compound 2; then compound 1.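

In this assay, going from 4-acetylphenyl to phenyl gives a 16-fold lower number from compound 1 to compound 3 (1.21 log units; beyond the scatter), a large step for a change at a single aromatic carbon, para to a large group. The fast clearance of compound 1 is therefore not set by the shared core and its side chains alone, since on that same core compound 3 gives 5 uL/min, and this position on the pendant ring emerges as a strong handle on the read-out, which the earlier pair, differing in more than one place, could not show. Nothing measured here accounts for the size of this step.

As far as these compounds go, it remains open whether the high number belongs to the acetyl group in particular or would return with other groups at this position, such as a nitrile, a primary amide, a methoxy or a 1-hydroxyethyl group. From the compounds shown here alone, the separate contributions of the trifluoromethyl and the chloro in compound 2 also remain open, as would be read from phenyl analogues carrying only one of the two.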